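Swapping 4-methoxyphenyl for 6-methoxypyridin-3-yl on the shared core

A few compounds are considered here, and "the series" means these few. Any claim that something is new, unique, unknown or untested is made for them only; others in the source may bear on it.

In a functional assay on HeLa cells (Homo sapiens) for antiproliferative activity, read by MTT assay, with a stated time of 72 h (a higher number here means a weaker inhibitor, a lower number a stronger inhibitor), compound 1 (`CC/C=C/C(=O)Nc1cccc(Oc2nc(Nc3cccc(C#N)c3)nc3c2CSCC3)c1`) gives 31800 nM. In the same test, compound 2 (`CC/C=C/C(=O)Nc1cccc(Oc2nc(Nc3ccc(OC)cc3)nc3c2CSCC3)c1`) gives 27200 nM. Among the measured compounds shown here, these are the only two numbers available and they lie within the scatter of each other, so compound 2 holds no rank of its own.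

Compound 3 (`CC/C=C/C(=O)Nc1cccc(Oc2nc(Nc3ccc(OC)nc3)nc3c2CSCC3)c1`) keeps the core of compound 2 and alters one group: 6-methoxypyridin-3-yl in place of 4-methoxyphenyl on a nitrogen on an aromatic ring. In words, 6-methoxypyridin-3-yl stands in place of 4-methoxyphenyl on a nitrogen on an aromatic ring.

For the measured compounds named here, one measured step bears on this position: a 1.2-fold lower number from compound 1 to compound 2 (0.07 log units; within the scatter). Going by the values given here, it exchanged a different pair of groups on the same nitrogen, and no measured pair shows what a hetero atom in this ring does. Among the compounds with values here, because a 1.2-fold lower number from compound 1 to compound 2 (0.07 log units; within the scatter) is the only guide, no step beyond the scatter is expected in this assay, and no direction is favoured. The expected change is a 1.0-fold lower number from compound 2 to compound 3 (0.00 log units; within the scatter). Compound 3 is estimated at 27000 nM, with an expected range of 13000 nM to 52000 nM.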

Compound 3, half-maximal inhibitory concentration: 31200 nM
Compound 3: the middle estimate sits 1.2-fold (0.06 log units) below what was measured; the measured number falls inside the stated range.
By their numbers in this assay, from the lowest: compounds 2, 3 and 1 (each within the scatter of the next).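

Setting a six-membered aromatic ring with 1 hetero atom in place of a ring of carbon only, with the methoxy group kept, left the number within the scatter in this assay (a 1.1-fold higher number from compound 2 to compound 3 (0.06 log units; within the scatter)). Among the compounds shown here, this extends what the earlier pair showed, since that pair compared only two rings of carbon alone, and the exchange of 6-methoxypyridin-3-yl for 3-cyanophenyl also stayed within the scatter (a 1.0-fold lower number from compound 1 to compound 3 (0.01 log units; within the scatter)). Across compounds 1, 2 and 3, then, these three groups on the nitrogen cannot be told apart in this test, and no information is at hand to explain that result.

The compounds shown leave open whether any group on this nitrogen can move the number beyond the scatter, for instance a ring carrying a piperazine or a carboxylic acid in place of the methoxy group. They also leave open whether the three groups would remain indistinguishable on a core that gives a markedly lower number in this test, since all three values here come from the one shared core.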